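Bromo for Chloro: A Small Swap at the Ring Edge

This account rests on a few compounds, and the source may have more. Where it says the series, first, only, none or still open, it means among the compounds named here.

Measured so far:
compound 1, `O=C(NC(=S)Nc1ccc(Oc2ccccc2)cc1)c1ccccc1`, 2100 nM in an assay for inhibition of epoxide hydrolase 1 (Homo sapiens), read by fluorescence, using microsomes; a lower number here means a stronger inhibitor, a higher number a weaker inhibitor;
compound 2, `O=C(NC(=S)Nc1ccc(Cl)cc1)c1ccccc1`, 1640 nM in this assay.

Compound 2 holds the lowest of the two numbers shown, but its nearest neighbour is compound 1, and the only measured step, a 1.3-fold lower number from compound 1 to compound 2 (0.11 log units; within the scatter), is within the scatter, so the two are not separated. Compound 3, `O=C(NC(=S)Nc1ccc(Br)cc1)c1ccccc1`, differs from compound 2 by bromo in place of chloro on an aromatic carbon. For the measured compounds named here, no measured step exchanges one halogen for another; the one step on record concerns a different group at the same place and was itself within the scatter, so it gives no direction. Compound 3 is therefore expected to show no step beyond the scatter, a 1.1-fold lower number from compound 2 to compound 3 (0.04 log units; within the scatter). The estimate for compound 3 in this assay is 1500 nM, with a range from 700 nM to 3200 nM.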

Compound 3, half-maximal inhibitory concentration: 3440 nM
Compound 3: middle estimate off by 2.3-fold (0.36 log units), on the low side; the measured number lies above the stated range.
By their numbers in this assay, from the lowest: compounds 2, 1 and 3 (each within the scatter of the next, the first and the last beyond it).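

In this assay, for the compounds shown here, this position responds to an exchange between two single heavy atoms: bromo in place of chloro gives a 2.1-fold higher number from compound 2 to compound 3 (0.32 log units; beyond the scatter) and is the first step here to pass beyond the scatter, though only modestly. Bromo in place of phenoxy gives a 1.6-fold higher number from compound 1 to compound 3 (0.21 log units; within the scatter) and leaves compound 1 and compound 3 unseparated, so the three numbers do not fall into a clear order at this place, with only compound 2 and compound 3 set apart. No available evidence bears on why the halogen exchange moved the number.

The compounds shown leave open whether fluoro or iodo at this place would continue the difference seen between chloro and bromo. They also leave open how a methyl, a methoxy or an amine would compare there.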